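The source may report more compounds than this note shows. Statements on the series, on what has been measured and on what is new or still open speak of the compounds shown alone.

Measured compounds:
compound 1 `Cn1nc(CN2CCCC2)nc1-c1ccc(C2CCCCC2)cc1` — 20 nM
compound 2 `Cn1nc(CN2CCCC2)nc1-c1ccc2ccsc2c1` — 64 nM

In an assay on membranes from Jurkat cells for displacement of a labelled ligand from Sigma non-opioid intracellular receptor 1 (Homo sapiens), read by scintillation counting, with a stated time of 2 h (a lower number here means a stronger inhibitor, a higher number a weaker inhibitor), compound 1 gives 20 nM and compound 2 gives 64 nM. Of the two, compound 1 has the lower number, and its gap to compound 2 lies beyond the usual scatter of repeat measurements, so compound 1 is the stronger of the two in this assay.

Compound 3 `Cn1nc(CN2CCCC2)nc1-c1ccc(C(C)(C)C)cc1` has not yet been measured. It differs from compound 1 in one place: tert-butyl in place of cyclohexyl on an aromatic carbon. The rest of the shared core, including the pyrrolidine-bearing side chain, is unchanged.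

Among the measured compounds shown here, no measured pair shows this kind of change, so there is no directly comparable step to lean on. Both groups are hydrocarbon and carry no donors or acceptors; the entering group is smaller. A modest weakening is expected, most likely within or just beyond the scatter. The step from compound 1 to compound 3 in this assay is estimated at a 2.0-fold higher number from compound 1 to compound 3 (0.30 log units; within the scatter). Compound 3 is therefore expected to give about 40 nM, within a range of 12 nM to 130 nM.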

Compound 3, inhibition constant: 7.5 nM
Compound 3: middle estimate off by 5.3-fold (0.73 log units), on the high side; measured number outside the range, below it.
By their numbers in this assay, from the lowest: compound 3; then compound 1; then compound 2.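

In this assay, putting tert-butyl in place of cyclohexyl on this aromatic carbon gives a 2.7-fold lower number from compound 1 to compound 3 (0.43 log units; beyond the scatter), so the carbon ring of compound 1 is not needed here, and a group with fewer heavy atoms and no ring is better tolerated in this one pair. Among the compounds shown here, this is the first direct view of what a change at this place does while the rest of the shared core stays fixed. Nothing in the available data explains the gain.

From the compounds shown here alone, whether a still smaller hydrocarbon group, such as isopropyl or methyl, would continue this direction remains open, since a single step cannot show a trend. Also open, going by these compounds, is how the assay would respond at this place to a group containing oxygen or nitrogen, such as methoxy or an amine.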